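This account rests on a few compounds, and the source may have more. Where it says the series, first, only, none or still open, it means among the compounds named here.

Working notes on the series. Of the compounds shown here, two have numbers so far: compound 1 `CCC(=O)N(Cc1ccc(OC)c(O)c1)c1cc(OC)c(OC)c(OC)c1` and compound 2 `C/C=C/C(=O)N(Cc1ccc(OC)c(O)c1)c1cc(OC)c(OC)c(OC)c1`, which differ only in the group on the carbonyl carbon of the amide. In a functional assay on KYSE-450 cells (Homo sapiens) for inhibition, read by MTT assay, with a stated time of 48 h (on this read-out lower numbers stand for stronger inhibition and higher numbers for weaker inhibition), compound 1 gives 98 nM, and compound 2 gives 67 nM. The step of a 1.5-fold lower number from compound 1 to compound 2 (0.17 log units; within the scatter) is small; compound 2 and compound 1 are therefore not separated beyond the scatter, and neither can be called the more potent of the two.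

Compound 3 `COc1ccc(CN(C(=O)C[Se]C#N)c2cc(OC)c(OC)c(OC)c2)cc1O` is the next member. Relative to compound 2 the change is a group of 4 heavy atoms (2 carbon, 1 nitrogen, 1 selenium; no ring) in place of a group of 3 heavy atoms (3 carbon; no ring), on a carbonyl carbon. For the measured compounds named here, the only measured step that bears on this position is the exchange of acyl groups from compound 1 to compound 2, and it moved the number by little. Going by the values given here, the incoming group, with its nitrogen and selenium and the triple bond outside aromatic rings, has no counterpart among the measured compounds, so the measured step gives only weak guidance. The expectation is therefore a number near that of compound 2, with a wide range to allow for the unprecedented group: compound 3 is estimated at 110 nM (range 35 nM to 400 nM), a step of a 1.6-fold higher number from compound 2 to compound 3 (0.22 log units; within the scatter), which is expected to remain within the scatter.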

Compound 3, half-maximal inhibitory concentration: 280 nM
Beside the measured number, compound 3's estimate is 2.5-fold (0.41 log units) below it, within the range that was stated.
By their numbers in this assay, from the lowest: compounds 2 and 1 (each within the scatter of the next); then compound 3.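

Until now, exchanging the acyl group on the amide had produced no step beyond the scatter, so this position could have seemed indifferent to the group it carries. In this assay the position proves to respond, with a 4.2-fold higher number from compound 2 to compound 3 (0.62 log units; beyond the scatter) and with a 2.9-fold higher number from compound 1 to compound 3 (0.46 log units; beyond the scatter) as the second measure of the same change, making compound 3 the weakest of the three. The direction of the change is the same from either reference compound, but nothing at hand explains it.

From the compounds shown here alone, it remains open whether the higher number belongs to the selenium atom, to the nitrile or to the group of 4 heavy atoms as a whole, and a cyanomethyl group or a sulfur atom in place of selenium on the carbonyl side chain would begin to separate these. The compounds shown also leave open how far the position tolerates other groups on the carbonyl carbon, such as a longer chain, an amine or a carboxylic acid, and whether the change in compound 3 would read the same way on other cell lines.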